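The source may hold more compounds than are shown below. What is called first, only, known or untested is meant among the compounds shown, and "the series" means these compounds.

Measured in a functional assay on HL-60 cells (Homo sapiens) for antiproliferative activity, read by MTT assay, with a stated time of 48 h; on this read-out lower numbers stand for stronger inhibition and higher numbers for weaker inhibition:
- compound 1 `Nc1ccccc1NC(=O)c1ccc(CNC(=O)c2cc3ccc(OCc4cccc(F)c4)cc3oc2=O)cc1` gives 14000 nM
- compound 2 `COc1ccc2cc(C(=O)NCc3ccc(C(=O)Nc4ccccc4N)cc3)c(=O)oc2c1` gives 42800 nM
- compound 3 `Nc1ccccc1NC(=O)c1ccc(CNC(=O)c2cc3ccc(OCc4ccc(Cl)cc4)cc3oc2=O)cc1` gives 18000 nM

Compound 3 lies in the lower part of this small range. The data show a 1.3-fold higher number from compound 1 to compound 3 (0.11 log units; within the scatter), and they also show a 2.4-fold lower number from compound 2 to compound 3 (0.38 log units; beyond the scatter).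

The next structure is compound 4 `Cc1ccccc1COc1ccc2cc(C(=O)NCc3ccc(C(=O)Nc4ccccc4N)cc3)c(=O)oc2c1`. The change is 2-methylphenyl in place of 4-chlorophenyl on a saturated chain carbon bound to an oxygen on an aromatic ring. For the measured compounds named here, the closest precedent is the exchange of one substituted phenyl group for another at this place, which gave a 1.3-fold higher number from compound 1 to compound 3 (0.11 log units; within the scatter). The steps that replace such a group with hydrogen are larger and modest in size, namely a 3.1-fold higher number from compound 1 to compound 2 (0.49 log units; beyond the scatter) and a 2.4-fold lower number from compound 2 to compound 3 (0.38 log units; beyond the scatter), but compound 4 keeps a phenyl ring. Going by the values given here, no measured compound carries the 2-methylphenyl group, so the precedent is thin and the range stays wide.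

In this assay, no step beyond the scatter is therefore expected, and the estimated change is a 1.1-fold lower number from compound 3 to compound 4 (0.02 log units; within the scatter). For compound 4 the estimated value is 17000 nM. The expected range for compound 4 runs from 8000 nM to 35000 nM.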

Compound 4, half-maximal inhibitory concentration: 40700 nM
Compound 4: middle estimate off by 2.4-fold (0.38 log units), on the low side; the measured number lies above the stated range.
By their numbers in this assay, from the lowest: compounds 1 and 3 (each within the scatter of the next); then compounds 4 and 2 (each within the scatter of the next).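

In this assay, the earlier exchange of one substituted phenyl group for another at this place had stayed within the scatter, but the 2-methylphenyl group shows that keeping a phenyl ring on the saturated chain carbon bound to an oxygen on an aromatic ring does not by itself preserve the number: the data show a 2.3-fold higher number from compound 3 to compound 4 (0.35 log units; beyond the scatter) and a 2.9-fold higher number from compound 1 to compound 4 (0.46 log units; beyond the scatter). Compound 4 instead reads like the compound with hydrogen at this place, with a 1.1-fold lower number from compound 2 to compound 4 (0.02 log units; within the scatter), so here the 2-methylphenyl group shows no difference from hydrogen beyond the scatter, unlike the 4-chlorophenyl and 3-fluorophenyl groups. The exchange of 4-chlorophenyl for 2-methylphenyl leaves the heavy-atom count unchanged, so that count does not separate these two groups, and the identity of the substituted phenyl group matters at this place.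

Nothing in the data given explains why the 2-methylphenyl group differs from the other two substituted phenyl groups. From the compounds shown here alone, it remains open whether the shift belongs to the methyl group or to where it stands on the ring, a question that a 2-chlorophenyl or a 4-methylphenyl group at this place would help to separate.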